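Swapping a methoxy for a methyl on the urea arm

The source may report more compounds than this note shows. Statements on the series, on what has been measured and on what is new or still open speak of the compounds shown alone.

Of the compounds shown here, three sharing one core have been measured in a functional assay on SMMC-7721 cells (Homo sapiens) for inhibition, read by MTT assay, with a stated time of 48 h; on this read-out higher numbers stand for weaker inhibition and lower numbers for stronger inhibition. Compound 1 `COc1cccc(NC(=O)Nc2cccc(-c3cccc4[nH]nc(N)c34)c2)c1` gives 2860 nM in this assay. Compound 2 `Nc1n[nH]c2cccc(-c3cccc(NC(=O)Nc4ccc(Cl)c(C(F)(F)F)c4)c3)c12` gives 1150 nM, a lower number beyond the scatter, so it is the stronger inhibitor of the pair. Compound 3 `Nc1n[nH]c2cccc(-c3cccc(NC(=O)Nc4cc(C(F)(F)F)cc(C(F)(F)F)c4)c3)c12` gives 3540 nM, which lies within the scatter of compound 1, so no order between the two can be read. Compound 1 therefore sits in the upper part of this small set. Compound 4 `Cc1ccc(NC(=O)Nc2cccc(-c3cccc4[nH]nc(N)c34)c2)cc1` is not yet measured; it differs from compound 1 by 4-methylphenyl in place of 3-methoxyphenyl on an amide-type nitrogen. Among the measured compounds shown here, no matched step of this kind exists among the measured compounds, so the step of a 1.1-fold lower number from compound 1 to compound 4 (0.04 log units; within the scatter) is expected to be small, within the scatter. Compound 4 is estimated at 2600 nM, with a range from 1000 nM to 6500 nM.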

Compound 4, half-maximal inhibitory concentration: 4450 nM
Compound 4: middle estimate off by 1.7-fold (0.23 log units), on the low side, within the range that was stated.
By their numbers in this assay, from the lowest: compound 2; then compounds 1, 3 and 4 (each within the scatter of the next).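

On the urea arm in this assay, 4-methylphenyl in place of 3-methoxyphenyl on the amide-type nitrogen gives a 1.6-fold higher number from compound 1 to compound 4 (0.19 log units; within the scatter). The oxygen and its hydrogen-bond acceptor can therefore be absent from this aryl group without a change that stands clear of the scatter, although the group and its ring number change together. Nothing measured here offers an explanation for this small step. On these data alone, a 3-methylphenyl group would separate those two changes, and it remains open whether a carboxylic acid or an amine on this ring would shift the number.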